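Fluoro Added to an Aryl Ether Amide Scaffold

A few compounds are considered here, and "the series" means these few. Any claim that something is new, unique, unknown or untested is made for them only; others in the source may bear on it.

Compound 1 `CNC(=O)c1cc(Oc2ccc(NC(=O)c3nn(-c4ccccc4C(F)(F)F)c(=O)cc3C)cc2F)ccn1`: in a functional assay on MCF7 cells (Homo sapiens) for cytotoxicity, read by MTT assay, with a stated time of 72 h (a lower number here means a stronger inhibitor, a higher number a weaker inhibitor), compound 1 gives 35700 nM
Compound 2 `Cc1cc(=O)n(-c2ccccc2C(F)(F)F)nc1C(=O)Nc1ccc(Oc2ncnc3ccsc23)c(F)c1`: in this assay compound 2 gives 6020 nM
Compound 3 `Cc1cc(=O)n(-c2ccccc2C(F)(F)F)nc1C(=O)Nc1ccc(Oc2ncnc3sccc23)cc1`: in this assay compound 3 gives > 40000 nM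

Compound 3 stands at the limit of this assay: its value of > 40000 nM is a limit and not a number, and the limit of > 40000 nM in this assay, at which 1 of the 3 values shown sits, states that one of the three values shown sits there. Compound 4 `Cc1cc(=O)n(-c2ccccc2C(F)(F)F)nc1C(=O)Nc1ccc(Oc2ncnc3sccc23)c(F)c1` differs from compound 3 in one place: fluoro in place of hydrogen on an aromatic carbon, the fluoro entering on a carbon ortho to a large group and meta to a large group.

Among the compounds with values here, no measured step follows this change. Within the data shown here, the only measured step, a 5.9-fold lower number from compound 1 to compound 2 (0.77 log units; beyond the scatter), concerns the group on the ether oxygen and says nothing about a fluoro. Compound 2 carries the fluoro and gives 6020 nM. Compound 2 and compound 3 differ in two places, so their gap cannot be assigned. Compound 4 is expected to give 12000 nM, with a range from 3000 nM to 40000 nM, and the step of an at least 3.3-fold lower number from compound 3 to compound 4 (0.52 log units; beyond the scatter) is an expectation only.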

Compound 4, half-maximal inhibitory concentration: 13800 nM
Compound 4: middle estimate off by 1.2-fold (0.06 log units), on the low side; low and high end bracket the measured number.
By their numbers in this assay, from the lowest: compound 2; then compound 4; then compound 1. At a limit, above all of these: compound 3.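

In this assay compound 3 gives > 40000 nM, which is a limit and not a number, so the step for the fluoro has only a lower bound: the limit of > 40000 nM in this assay, at which 1 of the 4 values shown sits. Even so, the change of hydrogen to fluoro on this aromatic carbon, ortho to a large group and meta to a large group, now has a measured step of its own, which lies beyond the scatter: an at least 2.8-fold lower number from compound 3 to compound 4 (0.46 log units; beyond the scatter). With the fluoro held in place, the group on the ether oxygen still moves the number in both directions, as two further steps show: a 2.3-fold higher number from compound 2 to compound 4 (0.36 log units; beyond the scatter), and a 2.6-fold lower number from compound 1 to compound 4 (0.41 log units; beyond the scatter).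

Going by these compounds, the full size of the fluoro step remains open, as does whether it would carry over to the groups on the ether oxygen of compound 1 and compound 2. On these data alone, whether a chloro or a methoxy on this carbon would act as the fluoro does is also open.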